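The source may hold more compounds than are shown below. What is called first, only, known or untested is meant among the compounds shown, and "the series" means these compounds.

Measured so far:
Compound 1 `CCCOP(=O)(O)OCCSC(=S)N1CCCCCC1` gives > 100000 nM in a functional assay on PC-3 cells (Homo sapiens) for inhibition, read by MTT assay, with stated times of 18 h and 4 h (a lower number here means a stronger inhibitor, a higher number a weaker inhibitor), which is a limit of the assay rather than a number.
Compound 2 `CCCCCCOP(=O)(O)OCCSC(=S)N1CCCCC1` gives > 100000 nM in this assay, again a limit.
Compound 3 `CCCCCCCCOP(=O)(O)OCCSC(=S)N1CCCC1` gives > 100000 nM in this assay, also a limit.

Compound 1 therefore stands at the limit of > 100000 nM in this assay, at which 3 of the 3 values shown sit, and none of the three measured values is a number. Among the compounds with values here, no measured compound differs from compound 1 in a single place, so no step between measured compounds can be drawn. Compound 4 `CCCCCCCCCCOP(=O)(O)OCCSC(=S)N1CCCCCC1` is the next to be measured. It differs from compound 1 by heptyl in place of hydrogen on a saturated chain carbon, three bonds along the chain from an oxygen on an unsaturated carbon. Within the data shown here, since every compound measured so far returned only a limit, there is no measured step on which to build a direction, and the expectation for compound 4 is that the change a number no higher from compound 1 to compound 4 (the limit leaves the size open) stays within the scatter, with another limit the most likely report. The estimate for compound 4 in this assay is 100000 nM, expected to fall between 30000 nM and 300000 nM.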

Compound 4, half-maximal inhibitory concentration: 32900 nM
Estimate against measurement, compound 4: 3.0-fold (0.48 log units) above; the range from low to high includes it.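

In this assay compound 4 is the only one of the compounds shown to return a number rather than a limit, 32900 nM. Heptyl in place of hydrogen on a saturated chain carbon, three bonds along the chain from an oxygen on an unsaturated carbon, gives an at least 3.0-fold lower number from compound 1 to compound 4 (0.48 log units; beyond the scatter), so this position on the core of compound 1 responds to chain extension in a way the earlier compounds could not show. That step is only a minimum, and its true size stays open, because the other end of it is a limit: the limit of > 100000 nM in this assay, at which 3 of the 4 values shown sit.

Within the data shown here, compounds 2 and 3 differ from compound 4 in more than one place, so no steps to them can be read. As far as these compounds go, whether a longer chain than heptyl at this place, or an amine in its stead, would lower the number further remains open.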